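Branching the Alkyl Chain on a Sulfonamide Series

The source may hold more compounds than are shown below. What is called first, only, known or untested is meant among the compounds shown, and "the series" means these compounds.

Three compounds have been measured in a functional assay on M21 cells (Homo sapiens) for antiproliferative activity, read by sulforhodamine B assay, with a stated time of 48 h; a higher number here means a weaker inhibitor, a lower number a stronger inhibitor:

Compound 1 `O=C1NCCN1c1ccc(S(=O)(=O)Nc2ccc3[nH]ccc3c2)cc1` gives 87 nM
Compound 2 `CCCCc1ccc(NS(=O)(=O)c2ccc(N3CCNC3=O)cc2)cc1` gives 450 nM
Compound 3 `O=C1NCCN1c1ccc(S(=O)(=O)Nc2cccc(Br)c2)cc1` gives 59 nM

Among these three, compound 2 has the highest number in this assay. Both compound 1 and compound 3 give lower numbers, and each of those gaps lies beyond the usual scatter of the measurement, so compound 2 is the weakest inhibitor of the three shown.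

Compound 4 `CC(C)Cc1ccc(NS(=O)(=O)c2ccc(N3CCNC3=O)cc2)cc1` is built from the same atoms as compound 2, joined differently. The difference is isopropyl in place of propyl on a saturated chain carbon bound to an aromatic carbon. Seen one bond further out, the butyl chain of compound 2 becomes an isobutyl chain in compound 4.

For the measured compounds named here, no pair of measured compounds shows a change of this kind, so there is no measured step to lean on. Rearranging the same three carbons on the chain is a small alteration, and the expectation is a step from compound 2 to compound 4 that stays within the scatter, with no clear direction. Compound 4 is therefore expected to give about 400 nM in this assay, within a range from 150 nM to 1100 nM, which corresponds to an expected step of a 1.1-fold lower number from compound 2 to compound 4 (0.05 log units; within the scatter).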

Compound 4, half-maximal inhibitory concentration: > 1000 nM
Compound 4 was reported as a limit (the forecaster's own chance of this, stated with the estimate: 3%); middle value at least 2.5-fold (0.39 log units) from the limit.
By their numbers in this assay, from the lowest: compounds 3 and 1 (each within the scatter of the next); then compound 2. At a limit, above all of these: compound 4.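

For the compounds shown here, this is the first measured step. It shows that the butyl chain of compound 2 cannot be rearranged freely: turning it into an isobutyl chain, with no atom gained or lost, gives an at least 2.2-fold higher number from compound 2 to compound 4 (0.34 log units; beyond the scatter) in this assay. So a branch in the chain alone is enough to weaken the compound in this pair, though the data do not say why. Compound 4 gives > 1000 nM, which is a limit and not a number: the limit of > 1000 nM in this assay, at which 1 of the 4 values shown sits.

On these data alone, it remains open whether this loss belongs to the isobutyl branch alone or would also appear with other groups in place of the butyl chain, such as a longer straight chain, an amine or a carboxylic acid. Compounds 1 and 3 cannot settle this, as they carry neither chain.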